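A few compounds are considered here, and "the series" means these few. Any claim that something is new, unique, unknown or untested is made for them only; others in the source may bear on it.

Compound 1 `Cc1ccccc1NC(=O)NCC1(c2ccccc2)CCCCC1`: 640 nM
Compound 2 `O=C(NCC1(c2ccccc2)CCCCC1)Nc1ccc(I)cc1`: 2300 nM

In an assay on microsomes from intestine for inhibition of acyl-CoA:cholesterol acyltransferase (Oryctolagus cuniculus) (on this read-out higher numbers stand for weaker inhibition and lower numbers for stronger inhibition), compound 1 stands lowest of the two numbers measured, and its nearest neighbour is compound 2, reached by a 3.6-fold higher number from compound 1 to compound 2 (0.56 log units; beyond the scatter), where 4-iodophenyl replaces 2-methylphenyl on an amide-type nitrogen. Compound 3 `Cc1cccc(C(C)C)c1NC(=O)NCC1(c2ccccc2)CCCCC1` keeps the shared core of compound 1 and differs from it only in isopropyl in place of hydrogen on an aromatic carbon, the new group sitting on an aromatic carbon of a six-membered aromatic ring of carbon only, ortho to a large group and meta to a methyl group. Among the compounds with values here, no measured step adds a group to this ring; the one step available exchanges the whole aryl group and moves the number by a modest amount. A step of similar or smaller size is therefore expected for the change from compound 1 to compound 3, with the direction uncertain. Compound 3 is estimated at 400 nM, in the range 120 nM to 1500 nM, which means an expected step of a 1.6-fold lower number from compound 1 to compound 3 (0.20 log units; within the scatter).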

Compound 3, half-maximal inhibitory concentration: 58 nM
Beside the measured number, compound 3's estimate is 6.9-fold (0.84 log units) above it; measured number below the stated range.
By their numbers in this assay, from the lowest: compound 3; then compound 1; then compound 2.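

Isopropyl in place of hydrogen on an aromatic carbon, ortho to a large group and meta to a methyl group, gives an 11-fold lower number from compound 1 to compound 3 (1.04 log units; beyond the scatter) in this assay and so counts as a large step. This shows that the position is sensitive: one added group here moves the number further than exchanging the whole aryl group did in a 3.6-fold higher number from compound 1 to compound 2 (0.56 log units; beyond the scatter) and, unlike that exchange, it moves the number downward. No independent measurement here speaks to the reason for this drop.

From the compounds shown here alone, it remains open whether ethyl, tert-butyl, methoxy or an amine on the same aromatic carbon would give a step of similar size or direction. Going by these compounds, it is also open whether isopropyl would lower the number in the same way on the 4-iodophenyl group of compound 2.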